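The compounds below may be only part of what the source reports. "The series", "measured", "known", "first", "only" and "open" are said of these compounds alone.

Among the compounds with values here, in a functional assay on RAW264.7 cells (Mus musculus) for inhibition, read by ELISA, with a stated time of 24 h (a higher number here means that more compound is needed for the effect, a lower number that less compound is needed), compound 1 (`CC/C=C\C[C@H]1C(=O)C=C[C@H]1CC(=O)Oc1ccc(O)cc1`) gives 23000 nM and compound 2 (`CC/C=C\C[C@H]1C(=O)C=C[C@H]1CC(=O)OCCOC`) gives 27000 nM, so compound 2 stands level with the only other number available. Compound 3 (`CC/C=C\C[C@H]1C(=O)C=C[C@H]1CC(=O)OC(C)(C)C`) keeps the shared core and carries tert-butyl in place of 2-methoxyethyl on an oxygen next to a carbonyl group. Within the data shown here, only one measured step bears on this change. It is a 1.2-fold higher number from compound 1 to compound 2 (0.07 log units; within the scatter), and it exchanges 4-hydroxyphenyl for 2-methoxyethyl on that same oxygen. Among the measured compounds shown here, that step is a different exchange, and no compound with tert-butyl has yet been measured, so it offers only indirect guidance. Even so, a shift beyond the scatter is not expected in this assay. The estimated change is a 1.1-fold lower number from compound 2 to compound 3 (0.03 log units; within the scatter). For compound 3 the expected value is 25000 nM, with an estimated range of 11000 nM to 55000 nM.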

Compound 3, half-maximal effective concentration: 20000 nM
Beside the measured number, compound 3's estimate is 1.3-fold (0.10 log units) above it; low and high end bracket the measured number.
By their numbers in this assay, from the lowest: compounds 3, 1 and 2 (each within the scatter of the next).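

With tert-butyl on this oxygen, this assay gives a 1.4-fold lower number from compound 2 to compound 3 (0.13 log units; within the scatter) and a 1.2-fold lower number from compound 1 to compound 3 (0.06 log units; within the scatter) so a group built of carbon alone now joins 4-hydroxyphenyl and 2-methoxyethyl, with all three numbers within the scatter of each other. Among these three compounds, neither the ring of 4-hydroxyphenyl nor the hydrogen-bond acceptor counted in 2-methoxyethyl is required to keep the number in this range. No supporting measurement is available to explain this result. Going by these compounds, whether an amine, a carboxylic acid or a longer chain on this oxygen would move the number beyond the scatter remains open. All three compounds differ only on this oxygen, and what a change elsewhere on the shared core would do is also unresolved.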